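The source may hold more compounds than are shown below. What is called first, only, known or untested is meant among the compounds shown, and "the series" means these compounds.

Compound 2 `COc1ccccc1N1CCN(CCNc2cc(-c3ccccc3)nn(C)c2=O)CC1`, compound 1 `COc1ccc(Cl)cc1N1CCN(CCCCNc2c(C(C)=O)c(C)nn(C)c2=O)CC1`, compound 3 `COc1ccccc1N1CCN(CCNc2c(C(=O)C(C)C)c(-c3ccccc3)nn(C)c2=O)CC1`.

In an assay on isolated protein for binding affinity to Alpha-1D adrenergic receptor (Homo sapiens), read by radioligand binding (on this read-out higher numbers stand for weaker inhibition and lower numbers for stronger inhibition), compound 2 gives 11.8 nM, the highest of the three numbers. Compound 1 gives 5.96 nM, within the scatter of compound 2, and compound 3 gives 0.43 nM, beyond it. For the measured compounds named here, the one measured step, a 27-fold lower number from compound 2 to compound 3 (1.44 log units; beyond the scatter), concerns a different position and does not cover the change now considered. Compound 4 `COc1ccccc1N1CCN(CCNc2cc(C)nn(C)c2=O)CC1` carries methyl in place of phenyl on an aromatic carbon. Going by the values given here, compound 1 also bears a methyl at that position but differs from compound 2 at several further places; its value shows only that such an analogue can sit near compound 2. Compound 4 is therefore expected close to compound 2, a modest rise being most likely: a 2.5-fold higher number from compound 2 to compound 4 (0.41 log units; beyond the scatter), estimated at 30 nM (range 8 nM to 120 nM).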

Compound 4, inhibition constant: 17.7 nM
Compound 4: the middle estimate sits 1.7-fold (0.23 log units) above what was measured; measured number inside the range.
By their numbers in this assay, from the lowest: compound 3; then compounds 1, 2 and 4 (each within the scatter of the next, the first and the last beyond it).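

Methyl in place of phenyl gives a 1.5-fold higher number from compound 2 to compound 4 (0.18 log units; within the scatter) in this assay, so with the rest of the core unchanged, the read-out at this position does not depend on keeping the phenyl ring. For the compounds shown here, this is the first comparison at this position that isolates the change, and it holds only for the pair carrying hydrogen where compound 3 carries isopropylcarbonyl. No available data explain this result.

Going by these compounds, whether methyl and phenyl remain equivalent alongside the isopropylcarbonyl of compound 3 stays open. So does the outcome with a butyl chain, an amine or a carboxylic acid at this position.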